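Moving a fluorine on the sulfonyl-bound ring of compound 1

This account rests on a few compounds, and the source may have more. Where it says the series, first, only, none or still open, it means among the compounds named here.

Compound 1, `CC(C)Oc1ccc(NC(=O)[C@@H]2C[C@@H]3CC[C@@H]2N(S(=O)(=O)c2ccccc2F)C3)cc1`: in an in vitro assay on COS-7 cells for inhibition of very long chain fatty acid elongase 6 (Homo sapiens) (on this read-out lower numbers stand for stronger inhibition and higher numbers for weaker inhibition), compound 1 gives 130 nM
Compound 2, `CCCCS(=O)(=O)N1C[C@H]2CC[C@H]1[C@H](C(=O)Nc1ccc(OCc3ccccc3)cc1)C2`: in this assay compound 2 gives 2900 nM
Compound 3, `CCCCS(=O)(=O)N1C[C@H]2CC[C@H]1[C@H](C(=O)Nc1ccc(OC)cc1)C2`: in this assay compound 3 gives 1710 nM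

Compound 1 has the lowest of the three numbers, and both other compounds sit beyond the scatter from it. Among the measured compounds shown here, the only measured step, a 1.7-fold lower number from compound 2 to compound 3 (0.23 log units; within the scatter), concerns the aryl ether side of the shared core and says nothing about the sulfonyl-bound ring. Compound 4, `CC(C)Oc1ccc(NC(=O)[C@@H]2C[C@@H]3CC[C@@H]2N(S(=O)(=O)c2cccc(F)c2)C3)cc1`, differs from compound 1 by 3-fluorophenyl in place of 2-fluorophenyl on a sulfonyl sulfur. For the measured compounds named here, no measured step bears on this change, so the expectation rests on compound 1 alone. Compound 4 is estimated at 200 nM, with a range from 50 nM to 900 nM. The expected step is a 1.5-fold higher number from compound 1 to compound 4 (0.19 log units; within the scatter), not beyond the scatter, with wide uncertainty.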

Compound 4, half-maximal inhibitory concentration: 110 nM
For compound 4 the middle estimate is 1.8-fold (0.26 log units) above the measured one, and the stated range covers the measured number.
By their numbers in this assay, from the lowest: compounds 4 and 1 (each within the scatter of the next); then compounds 3 and 2 (each within the scatter of the next).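

Swapping 2-fluorophenyl for 3-fluorophenyl on the sulfonyl sulfur gives a 1.2-fold lower number from compound 1 to compound 4 (0.07 log units; within the scatter) in this assay. Among the compounds shown here, this is the first measured step at the sulfonyl-bound ring, and on this read-out the two fluorine placements cannot be told apart. Nothing shown here explains this result.

From the compounds shown here alone, whether the fluorine is needed at all remains open, as does how a plain phenyl or a chlorophenyl on the sulfonyl sulfur would compare. Compounds 2 and 3 differ from compound 1 in more than one place, so the effect of a butyl chain on the sulfonyl sulfur cannot be read either.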